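From nitro to methyl on the aromatic ring

The compounds below may be only part of what the source reports. "The series", "measured", "known", "first", "only" and "open" are said of these compounds alone.

Values from a functional assay on HeLa cells (Homo sapiens) for inhibition, read by MTT assay, with a stated time of 72 h (a higher number here means a weaker inhibitor, a lower number a stronger inhibitor), for three measured compounds
compound 1 `Cc1ccc(-c2nnc(SCCCN3CCN(c4nc5ccccc5o4)CC3)o2)cc1` with 133000 nM
compound 2 `COc1ccc(-c2nnc(SCCCN3CCN(c4nc5ccccc5s4)CC3)o2)cc1` with 165000 nM
compound 3 `O=[N+]([O-])c1ccc(-c2nnc(SCCCN3CCN(c4nc5ccccc5s4)CC3)o2)cc1` with 97800 nM

Compound 3 gives 97800 nM in this assay and sits within the usual scatter of both compound 1 and compound 2, so these three numbers cannot be ranked.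

The next compound to be tested is compound 4 `Cc1ccc(-c2nnc(SCCCN3CCN(c4nc5ccccc5s4)CC3)o2)cc1`. It carries methyl in place of nitro on an aromatic carbon, para to a large group: methyl in place of nitro on an aromatic carbon is the whole difference from compound 3.

For the measured compounds named here, only one measured step touches this place: a 1.7-fold lower number from compound 2 to compound 3 (0.23 log units; within the scatter) with nitro in place of methoxy. That step stays within the scatter. Going by the values given here, no measured step swaps nitro for methyl directly, so this evidence is thin. Even so, it gives no reason to expect a large shift. The expected step is a 1.3-fold higher number from compound 3 to compound 4 (0.12 log units; within the scatter) and no change beyond the scatter is anticipated.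

In this assay compound 4 is estimated at 130000 nM (range 75000 nM to 220000 nM).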

Compound 4, half-maximal inhibitory concentration: 179000 nM
Beside the measured number, compound 4's estimate is 1.4-fold (0.14 log units) below it; the measured number falls inside the stated range.
By their numbers in this assay, from the lowest: compounds 3, 1, 2 and 4 (each within the scatter of the next).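

In this assay the direct change from 4-nitrophenyl to 4-methylphenyl gives a 1.8-fold higher number from compound 3 to compound 4 (0.26 log units; within the scatter) and so gives this position its first direct reading for this swap. Methyl in place of methoxy at this same place gives a 1.1-fold higher number from compound 2 to compound 4 (0.04 log units; within the scatter) while 1,3-benzothiazol-2-yl in place of 1,3-benzoxazol-2-yl on an amine nitrogen in a ring, a change at a second place, gives a 1.3-fold higher number from compound 1 to compound 4 (0.13 log units; within the scatter) and so none of the single changes shown moves the number beyond the scatter. Nothing measured here accounts for these small steps.

Still open, as far as these compounds go, is whether a quite different group on this aromatic carbon, such as an amine or a carboxylic acid, would shift the number beyond the scatter. The compounds shown also leave open whether any group at this place would bring the number far down from where these four lie.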